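From Trifluoromethyl to 1,1-Difluoroethyl: An Expected Value

The source may hold more compounds than are shown below. What is called first, only, known or untested is meant among the compounds shown, and "the series" means these compounds.

Measured so far in an ADME assay on cells for inhibition of cytochrome P450 11B1, mitochondrial (Homo sapiens), read by HPLC, with a stated time of 60 min; a lower number here means a stronger inhibitor, a higher number a weaker inhibitor:
compound 1 `Cc1ncncc1-c1nc2cc(F)c(F)cc2n1C1CC1` gives 4160 nM
compound 2 `CCc1ncncc1-c1nc2cc(F)c(F)cc2n1C1CC1` gives 3330 nM
compound 3 `Fc1cc2nc(-c3cncnc3C(F)(F)F)n(C3CC3)c2cc1F` gives 4770 nM

Compound 3 sits among the others with no step beyond the scatter: a 1.1-fold higher number from compound 1 to compound 3 (0.06 log units; within the scatter) and a 1.4-fold higher number from compound 2 to compound 3 (0.16 log units; within the scatter). Compound 4 `CC(F)(F)c1ncncc1-c1nc2cc(F)c(F)cc2n1C1CC1` carries methyl in place of fluoro on a saturated chain carbon bound to an aromatic carbon and two fluorine atoms. For the measured compounds named here, the steps that bear on this change are a 1.2-fold lower number from compound 1 to compound 2 (0.10 log units; within the scatter) and a 1.4-fold higher number from compound 2 to compound 3 (0.16 log units; within the scatter), both within the scatter, so the group on this carbon has so far not moved this assay beyond its noise. No step beyond the scatter is therefore expected in this assay for compound 4, and the step from compound 3 is estimated as a 1.2-fold lower number from compound 3 to compound 4 (0.08 log units; within the scatter). Compound 4 is expected to give about 4000 nM, within a range of 2000 nM to 8000 nM.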

Compound 4, half-maximal inhibitory concentration: 5720 nM
Estimate against measurement, compound 4: 1.4-fold (0.16 log units) below; measured number inside the range.
By their numbers in this assay, from the lowest: compounds 2, 1, 3 and 4 (each within the scatter of the next).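

In this assay, 1,1-difluoroethyl on this aromatic carbon stays within the scatter of every group compared with it: a 1.2-fold higher number from compound 3 to compound 4 (0.08 log units; within the scatter), a 1.7-fold higher number from compound 2 to compound 4 (0.23 log units; within the scatter) and a 1.4-fold higher number from compound 1 to compound 4 (0.14 log units; within the scatter). Methyl, ethyl, trifluoromethyl and 1,1-difluoroethyl now all give steps within the scatter of one another, so methyl in place of fluoro on this carbon also leaves the number unresolved. Nothing available explains this flat result. From the compounds shown here alone, whether an amine, a methoxy group or a longer chain here would move the number beyond the scatter remains open. Also open, going by these compounds, is whether this flatness would hold if the rest of the core of compound 1 carried other groups.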